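The source may report more compounds than this note shows. Statements on the series, on what has been measured and on what is new or still open speak of the compounds shown alone.

Measured: compound 1 `O=S(=O)(NCCCNCc1ccccc1Cl)c1cc(C(F)(F)F)cc(C(F)(F)F)c1` gives 11000 nM; compound 2 `O=S(=O)(NCCCNCc1ccc(Cl)cc1)c1cc(C(F)(F)F)cc(C(F)(F)F)c1` gives 2800 nM.

In a functional assay on MIA PaCa-2 cells (Homo sapiens) for inhibition, read by MTT assay, with a stated time of 72 h (on this read-out higher numbers stand for weaker inhibition of growth and lower numbers for stronger inhibition of growth), compound 2 holds the lower of the two numbers, compound 1 the higher. For the measured compounds named here, the single measured step is a 3.9-fold lower number from compound 1 to compound 2 (0.59 log units; beyond the scatter).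

Compound 3 `COc1ccccc1CNCCCNS(=O)(=O)c1cc(C(F)(F)F)cc(C(F)(F)F)c1` is unmeasured; it differs from compound 2 by 2-methoxyphenyl in place of 4-chlorophenyl on a saturated chain carbon bound to an amine nitrogen. The step that bears on it is a 3.9-fold lower number from compound 1 to compound 2 (0.59 log units; beyond the scatter), which joined 2-chlorophenyl to 4-chlorophenyl at this same place. Going by the values given here, compound 3 carries 2-methoxyphenyl, a ring whose substituent sits as in the 2-chlorophenyl of compound 1, yet the exchange of chlorine for methoxy itself has no measured counterpart, so only the direction is supported. In this assay compound 3 is expected to move back toward compound 1, a rise beyond the scatter, a 2.9-fold higher number from compound 2 to compound 3 (0.46 log units; beyond the scatter). Compound 3 is therefore estimated at 8000 nM, within 2500 nM to 25000 nM.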

Compound 3, concentration for 50% growth inhibition: 3100 nM
Beside the measured number, compound 3's estimate is 2.6-fold (0.41 log units) above it; low and high end bracket the measured number.
By their numbers in this assay, from the lowest: compounds 2 and 3 (each within the scatter of the next); then compound 1.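

In this assay the change from 4-chlorophenyl to 2-methoxyphenyl on a saturated chain carbon bound to an amine nitrogen reads as a 1.1-fold higher number from compound 2 to compound 3 (0.04 log units; within the scatter) and so leaves the two groups level at this place. Methoxy in place of chloro on an aromatic carbon reads as a 3.5-fold lower number from compound 1 to compound 3 (0.55 log units; beyond the scatter) and shows that the group itself counts here, so the number of compound 1 cannot be tied to the ring place of its substituent alone. Nothing on hand gives a reason for either step.

Open is whether 4-methoxyphenyl would stand apart from 2-methoxyphenyl as 4-chlorophenyl does from 2-chlorophenyl, and where an unsubstituted phenyl ring would fall among these groups. Also open, from the compounds shown here alone, is how a longer chain in the shared core would bear on these steps.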